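The compounds below may be only part of what the source reports. "The series", "measured", "known", "first", "only" and "open" are said of these compounds alone.

Compound 1 `Cc1ccc(O)c(C(=O)Nc2ccc([N+](=O)[O-])cc2Cl)c1`: < 1 ug/mL, a limit in a physicochemical assay for solubility; on this read-out higher numbers stand for higher solubility and lower numbers for lower solubility.
Compound 2 `CC(=O)c1ccc(O)c(C(=O)Nc2ccc([N+](=O)[O-])cc2Cl)c1`: > 49 ug/mL, also a limit in this assay.

Compound 2 holds the higher of the two readings, though its > 49 ug/mL is a limit and not a number. Compound 3 `O=C(Nc1ccc([N+](=O)[O-])cc1Cl)c1cc(-c2ccc(F)cc2F)ccc1O` has 2,4-difluorophenyl in place of acetyl on an aromatic carbon, para to a hydroxy group: 2,4-difluorophenyl in place of acetyl on an aromatic carbon. Among the measured compounds shown here, the one measured step at this place brought the acetyl in, and it was large: an at least 49-fold higher number from compound 1 to compound 2 (1.69 log units; beyond the scatter). Compound 3 gives up that acetyl, so a large downward step is expected in this assay. The estimated change is an at least 49-fold lower number from compound 2 to compound 3 (1.69 log units; beyond the scatter). For compound 3 the expected value is 1 ug/mL, within a range of 0.4 ug/mL to 5 ug/mL.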

Compound 3, solubility: < 1 ug/mL
Compound 3 ended at the assay's limit; the forecaster's own chance of this, stated with the estimate: 60%; the middle value lies on the limit itself.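

At this position, para to a hydroxy group, the high reading no longer follows from simply having a group other than methyl: in this assay, 2,4-difluorophenyl in place of acetyl gives an at least 49-fold lower number from compound 2 to compound 3 (1.69 log units; beyond the scatter). This step rests on limits, not on exact numbers. Compound 1 and compound 3 both sit at the same limit, so the step between them cannot be read.

From the compounds shown here alone, how an amine, a carboxylic acid or a longer chain would read at this place stays open. So does the true value of compound 2, which is only known as a limit: the limit of > 49 ug/mL in this assay, at which 1 of the 3 values shown sits.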